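A Branch Moved by One Carbon: Compound 3 Awaited

This account rests on a few compounds, and the source may have more. Where it says the series, first, only, none or still open, it means among the compounds named here.

Compound 1 `COc1cc(NC(C)CCCN2C(=O)[C@@H](C)N(C(=O)CN)C2(C)C)c2ncccc2c1` gives 2.54 in a physicochemical assay for lipophilicity, measured as octanol-water partition; on this read-out higher numbers stand for higher lipophilicity and lower numbers for lower lipophilicity.
Compound 2 `COc1cc(NC(C)CCCN2C(=O)CN(C(=O)[C@H](N)CC(C)C)C2(C)C)c2ncccc2c1` gives 3.36 in this assay.

Of these two numbers, compound 2 stands highest, and its nearest neighbour, compound 1, lies lower by a margin beyond the usual scatter. Compound 3 `CC[C@H](C)[C@@H](N)C(=O)N1CC(=O)N(CCCC(C)Nc2cc(OC)cc3cccnc23)C1(C)C` differs from compound 2 in one place: sec-butyl in place of isobutyl on a saturated chain carbon bound to an amine nitrogen and a carbonyl carbon. The two hold the same atoms joined differently. Within the data shown here, no measured pair shows this kind of change, so in this assay no step beyond the scatter is expected in either direction. The expected step is a number 0.06 log units lower from compound 2 to compound 3 (within the scatter). Compound 3 is therefore estimated at 3.3, within 3 to 3.6.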

Compound 3, partition coefficient: 3.4
Estimate against measurement, compound 3: 0.10 log units below, and the stated range covers the measured number.
By their numbers in this assay, from the lowest: compound 1; then compounds 2 and 3 (each within the scatter of the next).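

Sec-butyl in place of isobutyl on a saturated chain carbon bound to an amine nitrogen and a carbonyl carbon gives, in this assay, a step of a number 0.04 log units higher from compound 2 to compound 3 (within the scatter) for this one change. Among these compounds, this is the first one-place comparison in the set, which compound 1 and compound 2 could not give, and it leaves the two butyl isomers unseparated at this position. Nothing at hand bears on the reason for this result.

Still open, going by these compounds, is whether a longer chain, a phenyl ring or a carboxylic acid at this place would also stay within the scatter of compound 2.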